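Halogen swap on the aromatic ring of a pentacyclic ester

The source may hold more compounds than are shown below. What is called first, only, known or untested is meant among the compounds shown, and "the series" means these compounds.

Compound 1 `COC(=O)[C@@]1(C)CC[C@@H]2C3=C1CC[C@@H](C)[C@]3(C)C[C@@H]1c3ccccc3N[C@H]21` gives 39000 nM in a functional assay on A549 cells (Homo sapiens) for inhibition, read by sulforhodamine B assay, with a stated time of 48 h; a higher number here means a weaker inhibitor of growth, a lower number a stronger inhibitor of growth.
Compound 2 `COC(=O)[C@@]1(C)CC[C@@H]2C3=C1CC[C@@H](C)[C@]3(C)C[C@@H]1c3cccc(C)c3N[C@H]21` gives 30000 nM in this assay.
Compound 3 `COC(=O)[C@@]1(C)CC[C@@H]2C3=C1CC[C@@H](C)[C@]3(C)C[C@@H]1c3cccc(Br)c3N[C@H]21` gives 42000 nM in this assay.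

Compound 3 carries the highest of the three numbers, yet it lies within the scatter of both others: the step of a 1.1-fold higher number from compound 1 to compound 3 (0.03 log units; within the scatter) and the step of a 1.4-fold higher number from compound 2 to compound 3 (0.15 log units; within the scatter) are both small, as is a 1.3-fold lower number from compound 1 to compound 2 (0.11 log units; within the scatter). Nothing in these three measurements separates one compound from another.

Compound 4 `COC(=O)[C@@]1(C)CC[C@@H]2C3=C1CC[C@@H](C)[C@]3(C)C[C@@H]1c3cccc(Cl)c3N[C@H]21` differs from compound 3 by chloro in place of bromo on an aromatic carbon. Going by the values given here, the steps that bear on this change are those that already alter the same aromatic carbon: hydrogen to bromo in a 1.1-fold higher number from compound 1 to compound 3 (0.03 log units; within the scatter), methyl to bromo in a 1.4-fold higher number from compound 2 to compound 3 (0.15 log units; within the scatter), and hydrogen to methyl in a 1.3-fold lower number from compound 1 to compound 2 (0.11 log units; within the scatter), none of which left the scatter. Since three different groups at this carbon gave numbers that cannot be told apart, a fourth group, chloro, is expected to behave the same, and the step of a 1.1-fold lower number from compound 3 to compound 4 (0.04 log units; within the scatter) is estimated to stay within the scatter, with no clear direction.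

Compound 4 is therefore expected to give about 38000 nM in this assay, with a range from 15000 nM to 90000 nM.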

Compound 4, concentration for 50% growth inhibition: 54000 nM
For compound 4 the middle estimate is 1.4-fold (0.15 log units) below the measured one, and the stated range covers the measured number.
By their numbers in this assay, from the lowest: compounds 2, 1, 3 and 4 (each within the scatter of the next).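

In this assay chloro on this aromatic carbon stays level with the three groups seen there before, as a 1.3-fold higher number from compound 3 to compound 4 (0.11 log units; within the scatter) and a 1.4-fold higher number from compound 1 to compound 4 (0.14 log units; within the scatter) both show. Even the largest step at this carbon, a 1.8-fold higher number from compound 2 to compound 4 (0.26 log units; within the scatter), does not leave the scatter, so hydrogen, methyl, bromo and chloro cannot be told apart here, and the swap between the two halogens changes nothing that can be read. No measured evidence on these compounds bears on this result.

Whether any group at this carbon can move the number at all remains open, since an amine, a hydroxyl or a carboxylic acid does not appear among these compounds. Also open, from the compounds shown here alone, is whether the number responds to a change elsewhere on the shared core, such as replacing the methyl ester with a carboxylic acid or an amide.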